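Working notes: a smaller group on a carbonyl carbon

The source may report more compounds than this note shows. Statements on the series, on what has been measured and on what is new or still open speak of the compounds shown alone.

Of the compounds shown here, two have been read so far in an ADME assay on BE(2)-C cells (Homo sapiens) for cytotoxicity, read by MTT assay, with a stated time of 20 h; on this read-out higher numbers stand for lower toxicity in this test and lower numbers for higher toxicity in this test. Compound 1 `Cn1ccc(CNC(=O)C2CCN(C(=O)c3cc4ccccc4n3Cc3ccc(Cl)cc3)CC2)n1` returns > 100000 nM as a limit of the assay and not as a number. Going by the values given here, compound 2 `O=C(NCC1COc2cnccc21)C1CCN(C(=O)c2cc3ccccc3n2Cc2ccc(Cl)cc2)CC1` gives 75800 nM as the only actual number, so it has no measured neighbour to be ranked against. Compound 3 `O=C(c1cc2ccccc2n1Cc1ccc(Cl)cc1)N1CCC(C(=O)N2CCCC2)CC1` is still unread and carries a group of 5 heavy atoms (4 carbon, 1 nitrogen; one five-membered non-aromatic ring with 1 hetero atom) in place of a group of 11 heavy atoms (8 carbon, 2 nitrogen, 1 oxygen; one five-membered non-aromatic ring with 1 hetero atom, one six-membered aromatic ring with 1 hetero atom), on a carbonyl carbon in the form of pyrrolidin-1-yl on the carbonyl carbon. Among the compounds with values here, one measured step bears on this, at a different scale of change: an at least 1.3-fold lower number from compound 1 to compound 2 (0.12 log units; that floor lies within the scatter) is a floor within the scatter, and it rests on the limit of > 100000 nM in this assay, at which 1 of the 2 values shown sits, as one end. On that evidence, a 1.1-fold higher number from compound 2 to compound 3 (0.05 log units; within the scatter) is expected to stay within the scatter, with no direction favoured. For compound 3 the estimate is 85000 nM with an expected range of 40000 nM to 180000 nM in this assay as the read-out, and a report of only a limit would not be surprising.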

Compound 3, half-maximal cytotoxic concentration: 65600 nM
Compound 3: middle estimate off by 1.3-fold (0.11 log units), on the high side, within the range that was stated.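

Going by these compounds alone, on the carbonyl carbon in this assay, pyrrolidin-1-yl, with 0 hydrogen-bond donors and 0 hydrogen-bond acceptors, takes the place of the group of 11 heavy atoms and gives a 1.2-fold lower number from compound 2 to compound 3 (0.06 log units; within the scatter) as the first step at this place with a number at both ends. Neither the loss of the six-membered aromatic ring nor that of the amide hydrogen separates the two compounds on this read-out. The step of an at least 1.5-fold lower number from compound 1 to compound 3 (0.18 log units; that floor lies within the scatter) says little more, since compound 1 is reported only as a limit of the assay and not as a number: the limit of > 100000 nM in this assay, at which 1 of the 3 values shown sits.

On these data alone, whether any group on this carbonyl carbon moves the read-out beyond the scatter remains open. An amine, a carboxylic acid or a longer chain in place of pyrrolidin-1-yl would test this.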